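Pyridin-3-yl in Place of 4-(Dimethylamino)phenyl

A few compounds are considered here, and "the series" means these few. Any claim that something is new, unique, unknown or untested is made for them only; others in the source may bear on it.

Two compounds share one core and differ only in the ring attached to a carbon with a double bond to nitrogen. Compound 1 `O=C(N/N=C/c1cccc(O)c1)c1cccnc1Nc1cccc(C(F)(F)F)c1` carries 3-hydroxyphenyl there, and in a functional assay on the whole organism (strain Wistar) for inhibition, with Rattus norvegicus as the target, read by paw edema, with a stated time of 3 h, at a dose of 10 mg/kg by the intraperitoneal route (a higher number here means more inhibition at the dose given (going by the name of the read-out), a lower number less inhibition), compound 1 gives 49%. Compound 2 `CN(C)c1ccc(/C=N/NC(=O)c2cccnc2Nc2cccc(C(F)(F)F)c2)cc1` carries 4-(dimethylamino)phenyl instead, and in this assay compound 2 gives 39.5%. Among the compounds with values here, the only measured step is a number 9.5 percentage points lower from compound 1 to compound 2 (within the scatter). Of the two numbers shown, compound 2 stands at the lower one, but the gap to compound 1 is within the scatter, so no real difference has been established. Compound 3 `O=C(N/N=C/c1cccnc1)c1cccnc1Nc1cccc(C(F)(F)F)c1` brings the next change: pyridin-3-yl in place of 4-(dimethylamino)phenyl on a carbon with a double bond to nitrogen. Within the data shown here, no measured step involves pyridin-3-yl at this position, so the single recorded step, itself within the scatter, is the only guide, and it suggests that exchanging this ring does not move the read-out beyond the scatter. The step expected is a number 2.5 percentage points higher from compound 2 to compound 3 (within the scatter). Compound 3 is therefore estimated at 42%, between 25% and 60%.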

Compound 3, a percentage reported as inhibition, in the whole organism at one dose (the size of the read-out at that dose, not a potency): 52.4%
Compound 3: middle estimate off by 10.4 percentage points, on the low side; measured number inside the range.
By their numbers in this assay, from the lowest: compounds 2, 1 and 3 (each within the scatter of the next, the first and the last beyond it).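

In this assay, changing the ring on the carbon with a double bond to nitrogen now gives a step beyond the scatter, though a modest one (a number 12.9 percentage points higher from compound 2 to compound 3 (beyond the scatter)), so the read-out can respond to the group at this position. Pyridin-3-yl and 3-hydroxyphenyl cannot be told apart here (a number 3.4 percentage points higher from compound 1 to compound 3 (within the scatter)), and compound 1 lies within the scatter of both compound 2 and compound 3, so only the two ends of this short series are separated. Nothing available explains why the read-out differs between these rings.

From the compounds shown here alone, it remains open what an open chain such as butyl, or a phenyl ring carrying a carboxylic acid, would do on this carbon. It is also undecided whether the step depends on 4-(dimethylamino)phenyl leaving or on pyridin-3-yl entering.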